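Halogen swap on the phenoxy arm of compound 1

The source may hold more compounds than are shown below. What is called first, only, known or untested is meant among the compounds shown, and "the series" means these compounds.

Compound 1 `Nc1ccccc1NC(=O)c1ccc(COc2ccc(Br)cc2)cc1` carries a 2-aminophenyl amide on one side and a 4-bromophenoxy group on the other. In a functional assay on A549 cells (Homo sapiens) for antiproliferative activity, read by CCK-8 assay, with a stated time of 72 h (a lower number here means a stronger inhibitor, a higher number a weaker inhibitor), compound 1 gives 24400 nM, the highest number among the three measured compounds. The nearest is compound 3 `Nc1ccccc1NC(=O)/C=C/c1ccc(CN2CCc3ccccc32)cc1`, which in this assay gives 13400 nM; the two values lie within the scatter, so no order between compound 1 and compound 3 can be claimed. Compound 2 `O=C(/C=C/c1ccc(CN2CCc3ccccc32)cc1)NO` gives 5480 nM in this assay, the lowest number of the set and beyond the scatter from compound 1. Going by the values given here, the only step between measured compounds that differ in one place runs a 2.4-fold higher number from compound 2 to compound 3 (0.39 log units; beyond the scatter); it concerns the amide-type nitrogen, not the phenoxy ring, and does not bear on the change considered here.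

Compound 4 `Nc1ccccc1NC(=O)c1ccc(COc2ccc(F)cc2)cc1` differs from compound 1 by fluoro in place of bromo on an aromatic carbon. Among the compounds with values here, no measured pair exchanges one halogen for another on an aromatic carbon, so there is nothing to calibrate this step against. In the absence of such a precedent the step of a 1.2-fold higher number from compound 1 to compound 4 (0.09 log units; within the scatter) is expected to stay within the scatter. Compound 4 is therefore estimated at 30000 nM in this assay, with a range from 10000 nM to 90000 nM.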

Compound 4, half-maximal inhibitory concentration: 5370 nM
Compound 4: the middle estimate sits 5.6-fold (0.75 log units) above what was measured; measured number outside the range, below it.
By their numbers in this assay, from the lowest: compounds 4 and 2 (each within the scatter of the next); then compounds 3 and 1 (each within the scatter of the next).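

On the 4-bromophenoxy arm of compound 1, the aromatic carbon para to a large group is sensitive to the identity of the halogen: in this assay fluoro in place of bromo gives a 4.5-fold lower number from compound 1 to compound 4 (0.66 log units; beyond the scatter) with the rest of the structure unchanged. This is the only step shown that reads a change on the phenoxy ring, whereas the earlier step concerned the amide-type nitrogen, so this position now has a measured response of its own, and a single heavy-atom exchange is enough to move the number beyond the scatter. Nothing at hand accounts for the direction or size of this step.

The compounds shown hold only bromo and fluoro at this place, so it remains open how chloro, methoxy, trifluoromethyl or a plain hydrogen would read there, and whether the number follows the halogen in any ordered way. Also open, as far as these compounds go, is whether the exchange of bromo for fluoro reads the same with hydroxy in place of the 2-aminophenyl group on the amide-type nitrogen.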